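The source may hold more compounds than are shown below. What is called first, only, known or untested is meant among the compounds shown, and "the series" means these compounds.

Measured so far in a toxicity assay on THP-1 cells (Homo sapiens) for cytotoxicity, read by MTT assay; a lower number here means a stronger inhibitor of growth, a higher number a weaker inhibitor of growth:

- compound 1 `C/C(=N\NC(N)=S)c1sc(C)nc1C`: > 100 ug/mL
- compound 2 `C/C(=N\Nc1nc(-c2ccc(F)cc2)cs1)c1sc(C)nc1C`: > 100 ug/mL
- compound 3 `C/C(=N\Nc1nc(-c2ccc(F)cc2)cs1)c1sc(-c2ccccc2)nc1C`: > 100 ug/mL

Each of these entries is a limit of the assay and not a number. The series as a whole shows (the limit of > 100 ug/mL in this assay, at which 3 of the 3 values shown sit). Compound 3 therefore has no exact position, and its entry of > 100 ug/mL is a limit like the other two.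

The next compound, compound 4 `COc1ccc(-c2csc(N/N=C(\C)c3sc(-c4ccccc4)nc3C)n2)cc1`, differs from compound 3 in one place. It has methoxy in place of fluoro on an aromatic carbon, para to a large group, a change from 4-fluorophenyl to 4-methoxyphenyl (methoxy in place of fluoro on an aromatic carbon).

Going by the values given here, only one measured step is available, and it lies elsewhere in the molecule: a step that the two limits leave unreadable from compound 2 to compound 3. Its size cannot be read, so it gives no size to carry over. Among the compounds with values here, no measured compound shows this exchange of fluoro for methoxy.

The expectation therefore rests on the unbroken run of limits, and no step beyond the scatter is expected in this assay, in either direction. The estimated change is a step that the limit leaves unreadable from compound 3 to compound 4. For compound 4 the expected value is 130 ug/mL, with an estimated range from 50 ug/mL to 300 ug/mL.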

Compound 4, concentration for 50% growth inhibition: > 100 ug/mL
Compound 4 was reported as a limit; the forecaster's own chance of this, stated with the estimate: 75%; the middle value lies beyond the limit too.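

Compared with compound 3, compound 4 gives > 100 ug/mL in this assay; this is a limit of the assay and not a number, so no step between the two can be read. Every value shown now sits at the same limit: the limit of > 100 ug/mL in this assay, at which 4 of the 4 values shown sit.

The compounds shown leave open which change, if any, would bring a value that can be read as a number in this assay.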